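The source may hold more compounds than are shown below. What is called first, only, known or untested is meant among the compounds shown, and "the series" means these compounds.

The measured compounds, with their values in an ADME assay on HEK-293T cells (Homo sapiens) for cytotoxicity, read by CCK-8 assay, with a stated time of 24 h; on this read-out lower numbers stand for higher toxicity in this test and higher numbers for lower toxicity in this test:

Compound 1 `Cc1ccc(NC(=O)c2ccc(CN3CCCN(C)CC3)cc2)cc1-n1cc(-c2cnc3ccnn3c2)cn1`: 20500 nM
Compound 2 `Cc1ccc(NC(=O)c2ccc(F)cc2)cc1-n1cc(-c2cnc3cccnn23)cn1`: > 80000 nM
Compound 3 `Cc1ccc(NC(=O)c2cccc(Cl)c2)cc1-n1cc(-c2cnc3cccnn23)cn1`: > 80000 nM

Compound 1 stands as the only one of the three that gives a number in this assay; the other two give only limits. For compound 2 the value is a limit of this assay, not a number. For compound 3 the value is likewise a limit of this assay. The measured step that the two limits leave unreadable from compound 2 to compound 3 therefore cannot be read, both ends sitting at the limit of > 80000 nM in this assay, at which 2 of the 3 values shown sit.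

Compound 4 `Cc1ccc(NC(=O)c2ccc(C(F)(F)F)cc2)cc1-n1cc(-c2cnc3ccnn3c2)cn1` differs from compound 1 by trifluoromethyl in place of (4-methyl-1,4-diazepan-1-yl)methyl on an aromatic carbon. Going by the values given here, no measured step covers exactly this change. Among the compounds with values here, what the data show is that the one compound carrying the (4-methyl-1,4-diazepan-1-yl)methyl group, compound 1, gives a number, while the two compounds carrying a small halogenated group on the same ring, compound 2 and compound 3, both sit at the limit. Compound 4 joins the second group in structure, so the step of a 3.9-fold higher number from compound 1 to compound 4 (0.59 log units; beyond the scatter) is expected to run toward lower toxicity, and compound 4 may well reach the limit too.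

Compound 4 is thus estimated at 80000 nM, expected within 30000 nM to 200000 nM.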

Compound 4, half-maximal cytotoxic concentration: 43200 nM
Compound 4: the middle estimate sits 1.9-fold (0.27 log units) above what was measured, within the range that was stated.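

Going by these compounds alone, with the core of compound 1 held constant, trifluoromethyl in place of (4-methyl-1,4-diazepan-1-yl)methyl on this aromatic carbon gives a 2.1-fold higher number from compound 1 to compound 4 (0.32 log units; beyond the scatter) in this assay, the first step in the set that can be read as a size. The change therefore moves the read-out toward lower toxicity in this test, but only modestly, although the seven-membered ring and both of its nitrogen atoms are gone. Compound 4 still gives a number rather than a limit, so on this core a measurable value in this test does not depend on the (4-methyl-1,4-diazepan-1-yl)methyl group.

The compounds shown leave open whether a smaller amine such as a dimethylaminomethyl group, a six-membered piperazine or morpholine ring, a carboxylic acid, or a single fluorine or chlorine at this place on the same core would give a number close to that of compound 1, close to that of compound 4, or a limit. Compound 2 and compound 3 each give only a limit and not a number, and the step between them cannot be read: the limit of > 80000 nM in this assay, at which 2 of the 4 values shown sit.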